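The source may hold more compounds than are shown below. What is called first, only, known or untested is meant among the compounds shown, and "the series" means these compounds.

Measured so far in a functional assay on A549 cells (Homo sapiens) for antiproliferative activity, read by MTT assay, with a stated time of 48 h; on this read-out lower numbers stand for stronger inhibition and higher numbers for weaker inhibition:
- compound 1 `Cn1cc(-c2cnc3ccc(NC(=O)c4cccnc4)nc3c2)cn1`: > 50000 nM
- compound 2 `CCNc1ccc2ncc(-c3cnn(C)c3)cc2n1`: > 50000 nM

Compound 1 gives a limit and not a number. Compound 2, at > 50000 nM, is likewise only a limit, so it offers no number to step from. Among the compounds with values here, the series so far stands at the limit of > 50000 nM in this assay, at which 2 of the 2 values shown sit.

Compound 3 `Cn1cc(-c2cnc3ccc(NCC4CC4)nc3c2)cn1` keeps the core of compound 2 and changes one group: cyclopropyl in place of methyl on a saturated chain carbon bound to a nitrogen on an aromatic ring. In words, cyclopropyl replaces methyl on a saturated chain carbon bound to a nitrogen on an aromatic ring, which turns ethylamino into (cyclopropylmethyl)amino.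

Within the data shown here, the only measured step bearing on this is a step that the two limits leave unreadable from compound 1 to compound 2, and it gives no size to carry over. In this assay, the expected outcome is a number no higher from compound 2 to compound 3 (the limit leaves the size open), with no shift beyond the scatter expected in either direction. The estimate for compound 3 is 50000 nM, with an expected range of 15000 nM to 100000 nM.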

Compound 3, half-maximal inhibitory concentration: > 50000 nM
Compound 3: no number, only a limit; the forecaster's own chance of this, stated with the estimate: 75%; the middle value sits exactly at the limit.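

In this assay compound 3 gives > 50000 nM, which is a limit and not a number. Within the data shown here, no step among compound 1, compound 2 and compound 3 can therefore be read. The compounds shown leave open whether any change on the shared core gives a measurable value, as the series stands at one limit: the limit of > 50000 nM in this assay, at which 3 of the 3 values shown sit.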